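The compounds below may be only part of what the source reports. "The series", "measured", "known", "first", "only" and "open" are said of these compounds alone.

Working notes on the series. In a functional assay on brain (Rattus norvegicus, strain Wistar) for inhibition (on this read-out higher numbers stand for weaker inhibition and lower numbers for stronger inhibition), compound 1 `Cc1ccc(-c2c(C)[nH]c(=O)n2C)cc1` gives 85300 nM. Compound 2 `CCCc1ccc(-c2c(C)[nH]c(=O)n2C)cc1` differs from it by ethyl in place of hydrogen on a saturated chain carbon bound to an aromatic carbon and in this assay gives 21500 nM; the step is a 4.0-fold lower number from compound 1 to compound 2 (0.60 log units; beyond the scatter). Compound 3 `CCCCCCCCOc1ccc(-c2c(C)[nH]c(=O)n2C)cc1` carries a different core; the difference between the two cores is not broken down here. In this assay compound 3 gives 4000 nM, the lowest of the three numbers and beyond the scatter from both others. Compound 4 `CCCCCCCCCCOc1ccc(-c2c(C)[nH]c(=O)n2C)cc1` is not yet measured and differs from compound 3 by ethyl in place of hydrogen on a saturated chain carbon, eight bonds along the chain from an oxygen on an aromatic ring. Going by the values given here, this is the same kind of change as the one from compound 1 to compound 2, but there the ethyl entered on a saturated chain carbon bound to an aromatic carbon, whereas here it enters eight bonds along the chain from an oxygen on an aromatic ring. For compound 4 the expected step is a 2.0-fold lower number from compound 3 to compound 4 (0.30 log units; within the scatter). This rests on a 4.0-fold lower number from compound 1 to compound 2 (0.60 log units; beyond the scatter), set smaller as compound 3 already stands at 4000 nM. Compound 4 is estimated at 2000 nM, expected between 700 nM and 6000 nM.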

Compound 4, half-maximal inhibitory concentration: 6900 nM
The estimate for compound 4 lay 3.5-fold (0.54 log units) below the measured number, outside the stated range (above it).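

In this assay the new step reads a 1.7-fold higher number from compound 3 to compound 4 (0.24 log units; within the scatter), so on this core, ethyl in place of hydrogen at this chain carbon gives no change beyond the scatter. Set beside the earlier step, the same change does not carry over unchanged from one core to the other: the same change on two cores in this assay, a 4.0-fold lower number (0.60 log units; beyond the scatter) from compound 1 to compound 2 and a 1.7-fold higher number (0.24 log units; within the scatter) from compound 3 to compound 4, 6.8-fold (0.84 log units) apart, beyond the scatter of two such steps. Going by these compounds alone, this shows only that the two steps differ here; with a single pair per core, it does not show whether the core, the place of the ethyl or the chain already present accounts for the gap.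

The compounds shown leave open how a longer chain than that of compound 4, or an amine or a carboxylic acid in place of the chain, would read in this assay.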